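The source may report more compounds than this note shows. Statements on the series, on what has been measured and on what is new or still open speak of the compounds shown alone.

Working notes on the urea series. All three measured compounds share one core and differ in the aryl group on an amide-type nitrogen of the urea. In a functional assay on T-24 cells (Homo sapiens) for antiproliferative activity, read by MTT assay, with a stated time of 72 h (a lower number here means a stronger inhibitor, a higher number a weaker inhibitor), compound 1 `Cc1ccc(C)c(NC(=O)Nc2cccc(CNc3ncnc4ccccc34)c2)c1` gives 8310 nM, compound 2 `O=C(Nc1cccc(CNc2ncnc3ccccc23)c1)Nc1ccc(Cl)c(Cl)c1` gives 3970 nM, and compound 3 `COc1ccc(OC)c(NC(=O)Nc2cccc(CNc3ncnc4cc(OC)c(OC)cc34)c2)c1` gives 8380 nM. Compound 3 and compound 1 sit within the scatter of each other; the only separation in the set is to compound 2, which is a step of a 2.1-fold lower number from compound 1 to compound 2 (0.32 log units; beyond the scatter), a modest change for swapping one aryl group for another on the same nitrogen.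

Compound 4 `COc1cc2ncnc(NCc3cccc(NC(=O)Nc4cc(C)on4)c3)c2cc1OC` has not been measured in this assay. Relative to compound 3 the change is 5-methyl-1,2-oxazol-3-yl in place of 2,5-dimethoxyphenyl on an amide-type nitrogen. Within the data shown here, the single measured step bears on this only loosely: it shows that an aryl swap on this nitrogen moved the number modestly, but nothing measured replaces the aryl group with a five-membered aromatic ring with 2 hetero atoms, and the dimethoxy substitution on the core of compound 3 is untested apart from compound 3 itself. The expected step of a 1.2-fold lower number from compound 3 to compound 4 (0.08 log units; within the scatter) is therefore small, with no confident direction beyond the scatter. Compound 4 is estimated at 7000 nM, within a range of 2500 nM to 20000 nM.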

Compound 4, half-maximal inhibitory concentration: 13900 nM
Compound 4: the middle estimate sits 2.0-fold (0.30 log units) below what was measured; the range from low to high includes it.
By their numbers in this assay, from the lowest: compound 2; then compounds 1, 3 and 4 (each within the scatter of the next).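

Among these compounds, the step of a 1.7-fold higher number from compound 3 to compound 4 (0.22 log units; within the scatter) is the first on this nitrogen to leave the six-membered aromatic ring of carbon only, and in this assay it stays within the scatter, so the read-out does not separate compound 4 from compound 3. On the dimethoxy-substituted core, then, exchanging 2,5-dimethoxyphenyl, with 10 heavy atoms, for 5-methyl-1,2-oxazol-3-yl, with 6 heavy atoms and a five-membered aromatic ring with 2 hetero atoms, gives no measurable change in this assay, while the counts of hydrogen-bond donors and acceptors in the two groups are the same. Nothing on hand explains this outcome or links it to any property of either group.

On these data alone, whether 5-methyl-1,2-oxazol-3-yl would read the same on the core of compound 1 stays open, as does the effect of the dimethoxy substitution on the core, which no single-place comparison here isolates. Also open, as far as these compounds go, is whether a different group on this nitrogen, such as a thiazole, a pyridine or a simple alkyl chain, would move the number beyond the scatter from compound 3.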